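From a Bulky Sulfonyl to a Difluoropropyl Chain

This account rests on a few compounds, and the source may have more. Where it says the series, first, only, none or still open, it means among the compounds named here.

Compound 1, `CCSCCC12CCC(c3nnc(-c4ccccc4C(F)(F)F)n3C)(CC1)CC2`: 72%
Compound 2, `Cn1c(-c2ccccc2C(F)(F)F)nnc1C12CCC(CCS(C)(=O)=O)(CC1)CC2`: 63%
Compound 3, `Cn1c(-c2ccccc2C(F)(F)F)nnc1C12CCC(CCS(=O)(=O)C(C)(C)C)(CC1)CC2`: 10%

All three compounds share one core and differ only in the group on the saturated chain, and all were tested in a functional assay on the whole organism (strain ICR) for inhibition, with Mus musculus as the target, with a stated time of 16 h, at a dose of 10 mg/kg by the oral route; on this read-out higher numbers stand for more inhibition at the one dose given (going by the name of the read-out) and lower numbers for less inhibition. Compound 3 gives the lowest of the three numbers. Two measured steps end at it: a number 62 percentage points lower from compound 1 to compound 3 (beyond the scatter) and a number 53 percentage points lower from compound 2 to compound 3 (beyond the scatter). Both are large, and the second one changes only the group on the sulfonyl sulfur, tert-butyl in place of methyl. Compound 1 and compound 2 lie within the scatter of each other, so the one clear finding is that the (tert-butyl)sulfonyl goes with much less inhibition.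

Compound 4, `Cn1c(-c2ccccc2C(F)(F)F)nnc1C12CCC(CCCC(C)(F)F)(CC1)CC2`, has not been measured. (2,2-difluoropropyl in place of (tert-butyl)sulfonyl on a saturated chain carbon, two bonds along the chain from a saturated ring carbon). The 2,2-difluoropropyl is smaller than the group it replaces and carries no hydrogen-bond acceptors, so it is closer in size to the ethylsulfanyl of compound 1 than to the (tert-butyl)sulfonyl of compound 3. Because both a number 62 percentage points lower from compound 1 to compound 3 (beyond the scatter) and a number 53 percentage points lower from compound 2 to compound 3 (beyond the scatter) were large falls on arriving at the (tert-butyl)sulfonyl, removing it is expected to bring a large rise in this assay. Compound 4 is therefore estimated at 55%, with an expected range from 25% to 80%. Going by the values given here, that estimate means an expected a number 45 percentage points higher from compound 3 to compound 4 (beyond the scatter), a step upward beyond the scatter, though no measured compound carries a fluorinated chain and the exact size is uncertain.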

Compound 4, a percentage reported as inhibition, in the whole organism at one dose (the size of the read-out at that dose, not a potency): 94%
For compound 4 the middle estimate is 39 percentage points below the measured one; measured number above the stated range.
By their numbers in this assay, from the lowest: compound 3; then compounds 2 and 1 (each within the scatter of the next); then compound 4.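

At this place on the saturated chain, this assay records a number 84 percentage points higher from compound 3 to compound 4 (beyond the scatter), along with a number 31 percentage points higher from compound 2 to compound 4 (beyond the scatter) and a number 22 percentage points higher from compound 1 to compound 4 (beyond the scatter), so the 2,2-difluoropropyl stands above all three earlier groups. The earlier compounds shown here showed only that the (tert-butyl)sulfonyl goes with a low number, whereas compound 4 shows that a group with no sulfur at all can give more inhibition than either the ethylsulfanyl or the methylsulfonyl. Nothing measured here explains this rise.

The compounds shown leave open whether the fluorine atoms matter, which a plain propyl group in place of the 2,2-difluoropropyl would test. They also leave open how an amine or a carboxylic acid would fare in this same place.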